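Oxazole to Thiazole on a Fused Core

The source may hold more compounds than are shown below. What is called first, only, known or untested is meant among the compounds shown, and "the series" means these compounds.

Measured so far:
- compound 1 `Cc1oncc1-c1cccc2c1CCC2c1ncc[nH]1`, which in a functional assay on CHO cells for agonist activity at Alpha-1D adrenergic receptor (Homo sapiens), read by FLIPR and calcium flux (on this read-out higher numbers stand for an effect only at larger amounts of compound and lower numbers for an effect already at smaller amounts), gives > 10000 nM, a limit of the assay rather than a number.
- compound 2 `c1cc(-c2ncco2)c2c(c1)C(c1ncc[nH]1)CC2`, which in this assay gives 1390 nM.

Within the data shown here, compound 2 therefore holds the only actual number in this assay; the other value shown is a limit (the limit of > 10000 nM in this assay, at which 1 of the 2 values shown sits). Among the measured compounds shown here, the one measured step, an at least 7.1-fold lower number from compound 1 to compound 2 (0.85 log units; beyond the scatter), shows that swapping the five-membered ring on the aromatic carbon of the shared core can move the number well beyond the scatter. Compound 3 `c1cc(-c2nccs2)c2c(c1)C(c1ncc[nH]1)CC2` carries the change (1,3-thiazol-2-yl in place of 1,3-oxazol-2-yl on an aromatic carbon). For the measured compounds named here, no measured step compares these two rings directly, so the step from compound 2 is expected to be small, a 1.4-fold lower number from compound 2 to compound 3 (0.14 log units; within the scatter), and within the scatter. Compound 3 is thus estimated at 1000 nM in this assay, with a likely range from 300 nM to 4000 nM.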

Compound 3, half-maximal effective concentration: 3190 nM
Beside the measured number, compound 3's estimate is 3.2-fold (0.50 log units) below it; low and high end bracket the measured number.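

At this aromatic carbon, 1,3-oxazol-2-yl and 1,3-thiazol-2-yl are not interchangeable, although both are five-membered aromatic rings with the same counted hydrogen-bond donors and acceptors: in this assay, the change gives a 2.3-fold higher number from compound 2 to compound 3 (0.36 log units; beyond the scatter). Exchanging only the ring oxygen for sulfur is thus enough to move the number beyond the scatter, which the earlier pair could not show, as its two rings differ in more than that one atom. Placing 1,3-thiazol-2-yl where 5-methyl-1,2-oxazol-4-yl stood still gives an at least 3.1-fold lower number from compound 1 to compound 3 (0.49 log units; beyond the scatter), but this is only a bound, since the starting value is a limit: the limit of > 10000 nM in this assay, at which 1 of the 3 values shown sits.

On these data alone, all three groups here are five-membered aromatic rings, so how a phenyl ring, a pyridine or a carboxylic acid would read at this carbon remains open. As far as these compounds go, whether the same gap between oxazole and thiazole appears on a different core also remains open.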